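A few compounds are considered here, and "the series" means these few. Any claim that something is new, unique, unknown or untested is made for them only; others in the source may bear on it.

Working notes on the series. For the measured compounds named here, in a functional assay on MDA-MB-231 cells (Homo sapiens) for antiproliferative activity, read by MTT assay, with a stated time of 48 h (a lower number here means a stronger inhibitor, a higher number a weaker inhibitor), compound 1 `CN1CCN(c2ccc(-c3cc4c(N5CCN(C(=O)Nc6ccc(Cl)cc6)CC5)ncnc4s3)cc2)CC1` gives 5440 nM, and compound 2 `CN1CCN(c2ccc(-c3cc4c(N5CCN(C(=O)Nc6ccc(F)cc6F)CC5)ncnc4s3)cc2)CC1` gives 11400 nM, the higher of the two numbers so far. Compound 3 `CN1CCN(c2ccc(-c3cc4c(N5CCN(C(=O)Nc6cc(C(F)(F)F)ccc6F)CC5)ncnc4s3)cc2)CC1` changes one group of compound 2: 2-fluoro-5-(trifluoromethyl)phenyl in place of 2,4-difluorophenyl on an amide-type nitrogen. Going by the values given here, the only measured step on this amide-type nitrogen is a 2.1-fold higher number from compound 1 to compound 2 (0.32 log units; beyond the scatter), which is modest and just beyond the scatter. A step of similar modest size is therefore expected in this assay, though one step does not settle its direction. The expected change, leaning to a lower number, is a 1.4-fold lower number from compound 2 to compound 3 (0.15 log units; within the scatter). Compound 3 is estimated at 8000 nM, with an expected range of 3000 nM to 20000 nM.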

Compound 3, half-maximal inhibitory concentration: 9090 nM
For compound 3 the middle estimate is 1.1-fold (0.06 log units) below the measured one; the range from low to high includes it.
By their numbers in this assay, from the lowest: compounds 1, 3 and 2 (each within the scatter of the next, the first and the last beyond it).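

In this assay the change on this amide-type nitrogen gives a 1.3-fold lower number from compound 2 to compound 3 (0.10 log units; within the scatter) and a 1.7-fold higher number from compound 1 to compound 3 (0.22 log units; within the scatter) within the scatter in both cases. So 2-fluoro-5-(trifluoromethyl)phenyl cannot be told apart from either 2,4-difluorophenyl or 4-chlorophenyl here, although those two earlier groups differ from each other beyond the scatter. Nothing available bears on why these groups read as they do. Still open, on these data alone, is whether an amine or a carboxylic acid on the phenyl ring would shift the number beyond the scatter of all three compounds.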